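The source may report more compounds than this note shows. Statements on the series, on what has been measured and on what is new or still open speak of the compounds shown alone.

Working notes on the series. The reference point is compound 1, `O=C(NCc1ccc(N2CCCCCC2)c(F)c1)Nc1cccc2cnccc12`, which in a functional assay for antagonist activity at transient receptor potential cation channel subfamily V member 1 (Homo sapiens), read by calcium flux (a lower number here means a stronger inhibitor, a higher number a weaker inhibitor), gives 2.8 nM. Going by the values given here, compound 2, `CCN1CCc2cc(CNC(=O)Nc3cccc4[nH]ncc34)ccc21`, gives 285 nM in this assay; this is the highest of the two numbers known so far, and compound 1 shows a far lower number. Compound 3, `CCN1CCc2cc(CNC(=O)Nc3cccc4c3cnn4C)ccc21`, is the next member. Relative to compound 2 it carries methyl in place of hydrogen on an aromatic nitrogen. Among the compounds with values here, no pair of measured compounds shows this change, so its step is unknown; it is expected to be small, if anything toward a weaker inhibitor, as a 1.6-fold higher number from compound 2 to compound 3 (0.20 log units; within the scatter). For compound 3 the estimate is 450 nM, between 120 nM and 1800 nM.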

Compound 3, half-maximal inhibitory concentration: 305 nM
The estimate for compound 3 lay 1.5-fold (0.17 log units) above the measured number; measured number inside the range.
By their numbers in this assay, from the lowest: compound 1; then compounds 2 and 3 (each within the scatter of the next).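

On this aromatic nitrogen of the five-membered ring, methyl in place of hydrogen leaves the number in this assay unchanged within the scatter: a 1.1-fold higher number from compound 2 to compound 3 (0.03 log units; within the scatter). Going by these compounds alone, this is the first step read at this position, and it shows that the hydrogen on this nitrogen is not required to keep the number at this level. A methyl is accommodated here without a measurable cost.

On these data alone, whether an ethyl, a longer chain or a chain ending in an amine on this nitrogen would do the same remains open. No measurement at hand gives a reason for this result.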